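Limits only for two hydroxylated compounds

This account rests on a few compounds, and the source may have more. Where it says the series, first, only, none or still open, it means among the compounds named here.

Measured in a functional assay on HCT-15 cells (Homo sapiens) for inhibition; a higher number here means a weaker inhibitor, a lower number a stronger inhibitor:
compound 1 `Oc1ccccc1-c1cc(-c2ccccc2F)cc(-c2ccccc2O)n1` gives > 50000 nM as a limit of the assay
compound 2 `Oc1ccc(-c2cc(-c3ccccc3F)cc(-c3ccccc3O)n2)cc1` gives > 50000 nM as a limit of the assay

Compound 1 therefore stands at a limit and has no number in this assay at all. Compound 3 `Oc1ccccc1-c1cc(-c2ccc(C(F)(F)F)cc2)cc(-c2ccccc2O)n1` keeps the core of compound 1 and carries 4-(trifluoromethyl)phenyl in place of 2-fluorophenyl, opposite the ring nitrogen (4-(trifluoromethyl)phenyl in place of 2-fluorophenyl on an aromatic carbon). Within the data shown here, the only measured step (a step that the two limits leave unreadable from compound 1 to compound 2) concerns another group and has no readable size. The evidence (the limit of > 50000 nM in this assay, at which 2 of the 2 values shown sit) offers limits alone, so neither size nor direction can be carried over, and only a small, uncertain change is expected (an at least 1.2-fold lower number from compound 1 to compound 3 (0.09 log units; that floor lies within the scatter)). The estimate for compound 3 is 40000 nM as an expected value, with an expected range (10000 nM to 100000 nM).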

Compound 3, half-maximal inhibitory concentration: > 50000 nM
Compound 3: a limit, no number; the forecaster's own chance of this, stated with the estimate: 55%; middle value at least 1.2-fold (0.09 log units) from the limit.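

Compound 1 and compound 3 both stand at a limit in this assay, so the step between them cannot be read. The compounds shown leave open how strongly any of them inhibits in this assay.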